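One Group Swapped, One Exposure Value to Build On

The source may report more compounds than this note shows. Statements on the series, on what has been measured and on what is new or still open speak of the compounds shown alone.

Among the compounds with values here, compound 2 `CN(C)CC[C@H](CSc1ccccc1)Nc1ccc(S(=O)(=O)NC(=O)c2ccc(N3CCN(Cc4ccccc4-c4ccc(Cl)cc4)CC3)cc2)cc1S(=O)(=O)C(F)(F)F` is the only compound here with a number in an ADME assay on the whole organism (plasma, strain Sprague-Dawley) for pharmacokinetics, with Rattus norvegicus as the target, at a dose of 5 mg/kg by the oral route; a higher number here means more compound in the circulation at the dose given, a lower number less compound in the circulation: compound 2 gives 747 ng.h/mL. Compound 1 `CN(C)CC[C@H](CSc1ccccc1)Nc1ccc(S(=O)(=O)NC(=O)c2ccc(N3CCN(Cc4ccccc4-c4ccc(Cl)cc4)CC3)cc2)cc1S(C)(=O)=O` belongs to the same series, but in this assay compound 1 gives "not determined" (no result reported), so no result exists for it, and compound 2 therefore stands alone as the single reference point rather than as the best or worst of anything. Compound 3 `CN(C)CC[C@H](CSc1ccccc1)Nc1ccc(S(=O)(=O)NC(=O)c2ccc(N3CCN(Cc4ccccc4-c4ccc(Cl)cc4)CC3)cc2)cc1C(=O)C(F)(F)F` has not yet been measured. It differs from compound 2 in one place: (trifluoromethyl)carbonyl in place of (trifluoromethyl)sulfonyl on an aromatic carbon. Within the data shown here, no step between two measured compounds is available, so there is no precedent for what such a change does to exposure. Among the measured compounds shown here, with nothing to lean on beyond the single value of compound 2, the expected step in this assay is a 1.1-fold lower number from compound 2 to compound 3 (0.03 log units; within the scatter), which lies within the usual scatter and points in no particular direction. For compound 3 the estimated area under the concentration-time curve in this assay is 700 ng.h/mL, with a range from 250 ng.h/mL to 2000 ng.h/mL.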

Compound 3, area under the concentration-time curve: 1080 ng.h/mL
The estimate for compound 3 lay 1.5-fold (0.19 log units) below the measured number; measured number inside the range.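

At this position, on an aromatic carbon ortho to a large group and meta to a large group, the series now has its first readable step in this assay: putting (trifluoromethyl)carbonyl in place of (trifluoromethyl)sulfonyl gives a 1.4-fold higher number from compound 2 to compound 3 (0.16 log units; within the scatter), so the swap cannot be told apart from repeat-to-repeat variation. A sulfonyl-to-carbonyl exchange at this one place, with the trifluoromethyl part and the rest of the molecule left unchanged, is therefore compatible with oral exposure of the same order, and this position tolerates at least this one replacement without a clear loss or gain. No measurement shown here offers an explanation for this result.

Steps to compound 1 cannot be read. Still open, on these data alone, is whether a different kind of group at this position, such as a nitrile or a carboxylic acid, would keep exposure in the same range, and whether the same exchange would behave alike if other parts of the shared core were changed.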